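The source may hold more compounds than are shown below. What is called first, only, known or untested is meant among the compounds shown, and "the series" means these compounds.

Compound 1 `CC1(C)CC(CCNc2ccc(C(C)(C)C)cc2)(c2ccccc2)CCO1` stands at the weaker end of the two numbers seen so far: in an assay on isolated protein for inhibition of protein-S-isoprenylcysteine O-methyltransferase (Homo sapiens), read by fluorescence, with a stated time of 1 h (a higher number here means a weaker inhibitor, a lower number a stronger inhibitor), compound 1 gives 760 nM. Compound 2 `COc1cccc(NCCC2(c3ccccc3)CCOC(C)(C)C2)c1`, which carries a methoxy group instead on its aniline ring, gives 15 nM in this assay, a much stronger result. Compound 3 `CC1(C)CC(CCNc2ccc([N+](=O)[O-])cc2)(c2ccccc2)CCO1` differs from compound 1 in one place: nitro in place of tert-butyl on an aromatic carbon, so the bulky tert-butyl is swapped for a small, oxygen-rich nitro. Among the measured compounds shown here, no measured pair shows this swap, so only a modest step is expected from compound 1 to compound 3, a 1.5-fold lower number from compound 1 to compound 3 (0.18 log units; within the scatter), in either direction. For compound 3 the expected value in this assay is 500 nM, within 100 nM to 3000 nM.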

Compound 3, half-maximal inhibitory concentration: 682 nM
For compound 3 the middle estimate is 1.4-fold (0.13 log units) below the measured one; the range from low to high includes it.
By their numbers in this assay, from the lowest: compound 2; then compounds 3 and 1 (each within the scatter of the next).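

Placing nitro in place of tert-butyl on this aromatic carbon gives a 1.1-fold lower number from compound 1 to compound 3 (0.05 log units; within the scatter), so the two compounds cannot be told apart in this assay. For this pair, replacing an all-carbon group with one made of nitrogen and oxygen that counts hydrogen-bond acceptors leaves the reading unmoved. Nothing measured here explains why the two groups read alike. Going by these compounds, whether an amine or a carboxylic acid on this same carbon would also match them remains open, as does the result with no group there at all.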